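Fluorophenyl ester series: lipophilicity notes toward compound 3

A few compounds are considered here, and "the series" means these few. Any claim that something is new, unique, unknown or untested is made for them only; others in the source may bear on it.

Measured so far in a physicochemical assay for lipophilicity; a lower number here means a more polar compound, a higher number a more lipophilic compound:
compound 1 `C=CCc1ccc(OC(=O)C2CCCCC2)c(OC)c1` gives 3.52
compound 2 `C=CCc1ccc(OC(=O)c2ccccc2F)c(OC)c1` gives 2.7

Going by the values given here, compound 2 holds the lowest of the two numbers in this assay; its only neighbour is compound 1, and the step of a number 0.82 log units lower from compound 1 to compound 2 (beyond the scatter) separates them.

Compound 3 `C=CCc1ccc(OC(=O)c2ccc(F)cc2)c(OC)c1` has not yet been measured. It differs from compound 2 in one place: 4-fluorophenyl in place of 2-fluorophenyl on a carbonyl carbon. Among the compounds with values here, no measured step bears on this change. Within the data shown here, the single step in hand, a number 0.82 log units lower from compound 1 to compound 2 (beyond the scatter), exchanges cyclohexyl for 2-fluorophenyl and does not compare 2-fluorophenyl with 4-fluorophenyl, so it gives no guide to the size or direction of this move. With the same atoms joined differently, the expectation is a step within the scatter, estimated at a number 0.15 log units higher from compound 2 to compound 3 (within the scatter). Compound 3 is therefore expected to give about 2.85 in this assay, with a range from 2.45 to 3.25.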

Compound 3, partition coefficient: 2.7
For compound 3 the middle estimate is 0.15 log units above the measured one; measured number inside the range.
By their numbers in this assay, from the lowest: compounds 2 and 3 (each within the scatter of the next); then compound 1.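

In this assay, 4-fluorophenyl in place of 2-fluorophenyl on a carbonyl carbon gives no change at the digits printed from compound 2 to compound 3 (within the scatter), so the two fluorophenyl esters cannot be told apart in this read-out. Cyclohexyl replaced by 4-fluorophenyl gives a number 0.82 log units lower from compound 1 to compound 3 (beyond the scatter), matching a number 0.82 log units lower from compound 1 to compound 2 (beyond the scatter), so the earlier drop is not particular to 2-fluorophenyl. No supporting measurement is available to explain these numbers.

The compounds shown do not separate the contribution of the fluorine from that of the aromatic ring, as plain phenyl would be needed for that comparison. As far as these compounds go, it also remains open whether the two placements would still read alike with a group other than fluorine, such as an amine or a carboxylic acid.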